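Replacing the chlorophenyl ring of compound 1

This account rests on a few compounds, and the source may have more. Where it says the series, first, only, none or still open, it means among the compounds named here.

Values measured so far in a toxicity assay on J774.A1 cells (Mus musculus) for cytotoxicity, read by SYBR Green assay, with a stated time of 1 h; on this read-out higher numbers stand for an effect only at larger amounts of compound and lower numbers for an effect already at smaller amounts
- compound 1 (`CN(C)c1ccc2cc(-c3cccc(Cl)c3)c(N)nc2c1`) with 13000 nM
- compound 2 (`CN(C)c1ccc2cc(-c3cc(Cl)cc(Cl)c3)c(N)nc2c1`) with 3700 nM

Within the data shown here, compound 1, at 13000 nM, holds the higher of the two numbers in this assay, and compound 2 is its only neighbour. Among the measured compounds shown here, the single measured step, a chloro in place of hydrogen on an aromatic carbon, runs a 3.5-fold lower number from compound 1 to compound 2 (0.55 log units; beyond the scatter) and is modest.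

Compound 3 (`CN(C)c1ccc2cc(-c3ncccc3F)c(N)nc2c1`) has not yet been measured. It carries 3-fluoropyridin-2-yl in place of 3-chlorophenyl on an aromatic carbon of the shared core (3-fluoropyridin-2-yl in place of 3-chlorophenyl on an aromatic carbon). For the measured compounds named here, no measured step covers this exchange directly, and two compounds establish no trend. Going by the values given here, the only guide is compound 2, whose step (a 3.5-fold lower number from compound 1 to compound 2 (0.55 log units; beyond the scatter)) shows that adding a chloro lowered the number. Compound 3 has no chloro at all, so a modest step toward a higher number is expected, though with wide uncertainty. The estimated change is a 1.5-fold higher number from compound 1 to compound 3 (0.19 log units; within the scatter) in this direction. For compound 3 the estimated value is 20000 nM, with an expected range from 8000 nM to 50000 nM as its bounds.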

Compound 3, half-maximal effective concentration: 16000 nM
Estimate against measurement, compound 3: 1.3-fold (0.10 log units) above, within the range that was stated.
By their numbers in this assay, from the lowest: compound 2; then compounds 1 and 3 (each within the scatter of the next).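

In this assay, the exchange of 3-chlorophenyl for 3-fluoropyridin-2-yl on the aromatic carbon ortho to an amino group gives a 1.2-fold higher number from compound 1 to compound 3 (0.09 log units; within the scatter), so this change of the whole group leaves the number within the scatter. The earlier pair had shown only that a further chloro on the phenyl ring went with a lower number, whereas this step shows that a ring with a nitrogen, a fluorine and no chlorine can stand at this position with no change in the number that can be read. The entering group also counts one hydrogen-bond acceptor where the leaving group counts none, and this difference too comes with no readable change, although nothing available bears on why the number stayed level.

The single step changes the ring atom and the halogen together, so the compounds shown cannot separate what each contributes, and they leave open whether the two differences offset each other or neither matters here. Also open, as far as these compounds go, is how this assay would respond to a plain phenyl, a pyridin-2-yl without the fluorine, or a ring carrying a methoxy group or a carboxylic acid at this position.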